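A few compounds are considered here, and "the series" means these few. Any claim that something is new, unique, unknown or untested is made for them only; others in the source may bear on it.

Among the compounds with values here, in a functional assay on PC-3 cells (Homo sapiens) for cytotoxicity (a lower number here means that less compound is needed, a higher number that more compound is needed for the effect), compound 2 `COC1=C(C)C(=O)/C(=C(O)/C=C/c2ccco2)C(=O)C1(C)C` gives 20.6 ug/mL, the only true number so far. Compound 1 `COC1=C(C)C(=O)/C(=C(O)/C=C/c2ccc(O)cc2)C(=O)C1(C)C` gives > 20 ug/mL, which is a limit and not a number, as the limit of > 20 ug/mL in this assay, at which 1 of the 2 values shown sits, records. Within the data shown here, the only measured step is a step that the limit leaves unreadable from compound 1 to compound 2, so it offers no size to carry forward. The change to compound 3 `COC1=C(C)C(=O)/C(=C(O)/C=C/c2nccs2)C(=O)C1(C)C` is 1,3-thiazol-2-yl in place of furan-2-yl on a double-bonded chain carbon bound to a double-bonded chain carbon, with 1,3-thiazol-2-yl in place of furan-2-yl. Nothing measured points in either direction, so no shift beyond the scatter is expected, and the expected step is a 1.0-fold lower number from compound 2 to compound 3 (0.01 log units; within the scatter). For compound 3 the estimated value is 20 ug/mL, with a range from 9 ug/mL to 45 ug/mL.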

Compound 3, concentration for half-maximal effect: 10.8 ug/mL
Beside the measured number, compound 3's estimate is 1.9-fold (0.27 log units) above it; low and high end bracket the measured number.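

In this assay, this position now gives its first step between two real numbers, a 1.9-fold lower number from compound 2 to compound 3 (0.28 log units; within the scatter), so furan-2-yl and 1,3-thiazol-2-yl cannot be told apart here, despite the extra hetero atom in the ring. Against 4-hydroxyphenyl the reading is an at least 1.8-fold lower number from compound 1 to compound 3 (0.26 log units; that floor lies within the scatter), which is only a floor. Compound 1 carries a limit, not a number: the limit of > 20 ug/mL in this assay, at which 1 of the 3 values shown sits.

As far as these compounds go, whether an amine or a carboxylic acid in this place would move the number beyond the scatter stays open.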